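The compounds below may be only part of what the source reports. "The series", "measured", "known", "first", "only" and "open" are said of these compounds alone.

Compound 1 `CC1OC2(C=CC(=O)C=C2)N(c2nc(-c3ccc4ccccc4c3)nn2-c2ccccc2)C1=O` is tested in a functional assay on HeLa cells (Homo sapiens) for antiproliferative activity, with a stated time of 5 days (a lower number here means a stronger inhibitor, a higher number a weaker inhibitor), where compound 1 gives 120 nM. Its closest relative among the measured compounds is compound 2 `COc1ccc(-n2nc(-c3ccc4ccccc4c3)nc2N2C(=O)C(C)OC23C=CC(=O)C=C3)cc1`, which in this assay gives 140 nM. The two differ by a 1.2-fold higher number from compound 1 to compound 2 (0.07 log units; within the scatter), with a methoxy in place of hydrogen on an aromatic carbon. For the measured compounds named here, compound 1 thus shows the lower of the two numbers measured so far, but by a margin within the scatter, so the two cannot be told apart.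

Compound 3 `O=C1C=CC2(C=C1)OCC(=O)N2c1nc(-c2ccc3ccccc3c2)nn1-c1ccccc1` is the next compound to be measured. Relative to compound 1, (hydrogen in place of methyl on a saturated ring carbon). Going by the values given here, the only measured step concerns a different part of the structure, the aromatic carbon that carries the methoxy group, and it moved the number by just a 1.2-fold higher number from compound 1 to compound 2 (0.07 log units; within the scatter); no measured step touches the saturated ring carbon. With nothing directly comparable, the expectation is a small change, a 1.3-fold higher number from compound 1 to compound 3 (0.10 log units; within the scatter), within the usual scatter. The estimate for compound 3 in this assay is therefore 150 nM, with a range from 60 nM to 400 nM.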

Compound 3, half-maximal inhibitory concentration: 120 nM
Estimate against measurement, compound 3: 1.3-fold (0.10 log units) above, within the range that was stated.
By their numbers in this assay, from the lowest: compounds 1, 3 and 2 (each within the scatter of the next).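

At the saturated ring carbon next to the ring oxygen, hydrogen in place of methyl gives no change at the digits printed from compound 1 to compound 3 (within the scatter) in this assay. For the compounds shown here, this is the first look at this position, and it shows that the methyl group can be removed without any measurable loss in this read-out, so the methyl is not needed to hold the number at this level. Nothing available here explains why the number holds when the methyl group is removed.

On these data alone, only hydrogen and methyl appear at this carbon, so it remains open whether an ethyl, a hydroxymethyl or an aminomethyl group there would also leave the number in place, or whether the position tolerates only very small groups. As far as these compounds go, it is also open whether the methoxy group on the aromatic carbon of compound 2 would behave the same way on the core of compound 3, which carries hydrogen at the saturated ring carbon.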